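Methyl Becomes Ethyl on an Otherwise Unchanged Core

A few compounds are considered here, and "the series" means these few. Any claim that something is new, unique, unknown or untested is made for them only; others in the source may bear on it.

Compound 2 `Cc1ncn2c(O)nncc12` was measured in a functional assay for inhibition, with Homo sapiens as the target; a lower number here means a stronger inhibitor, a higher number a weaker inhibitor. In this assay compound 2 gives > 48000 nM, which is a limit of the assay and not a number. Compound 1 `CNc1nncc2c(C)ncn12` carries methylamino where compound 2 carries hydroxy on an aromatic carbon. In this assay compound 1 gives > 48000 nM, again a limit. The step that the two limits leave unreadable from compound 1 to compound 2 can therefore not be read. Compound 3 `CCc1nc(C)c2cnnc(O)n12` carries an ethyl where compound 2 carries hydrogen on an aromatic carbon. In this assay compound 3 gives > 48000 nM, once more a limit. The step that the two limits leave unreadable from compound 2 to compound 3 is likewise unreadable. All three measured values sit at the limit of > 48000 nM in this assay, at which 3 of the 3 values shown sit.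

Compound 4 `CCc1ncn2c(O)nncc12` is not yet measured. It differs from compound 2 by methyl in place of hydrogen on a saturated chain carbon bound to an aromatic carbon; cut one bond further out, the change reads methyl to ethyl. Both measured steps run between limits; neither offers a readable size for this change. For the measured compounds named here, the numbers so far point to no step in this assay in either direction, and to none beyond the scatter. The estimate for compound 4 in this assay is 60000 nM, within 20000 nM to 200000 nM, with the most likely outcome that the assay again reports only a limit. The expected step that the limit leaves unreadable from compound 2 to compound 4 is accordingly none beyond the scatter.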

Compound 4, half-maximal inhibitory concentration: > 48000 nM
Compound 4 ended at the assay's limit; the forecaster's own chance of this, stated with the estimate: 85%; the middle value is on the limit's open side.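

Compound 4 gives > 48000 nM in this assay, again a limit and not a number. For the compounds shown here, compound 2 also stands at a limit, so no step from compound 2 to compound 4 can be read. The compounds shown leave open whether any change on the shared core shifts the result in this assay, as all of them sit at one value: the limit of > 48000 nM in this assay, at which 4 of the 4 values shown sit.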